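The compounds below may be only part of what the source reports. "The series", "measured", "known", "first", "only" and "open" are said of these compounds alone.

Compound 2 `O=C(N/N=C\c1cn(Cc2ccc(Cl)cc2)c2cc(F)ccc12)c1c[nH]c2ccccc12` gives 19500 nM in a functional assay on PC-3 cells (Homo sapiens) for cytotoxicity; a lower number here means a stronger inhibitor, a higher number a weaker inhibitor.
Compound 3 `COc1ccc(Cn2cc(/C=N\NC(=O)c3c[nH]c4ccccc34)c3ccc(F)cc32)cc1` gives 18400 nM in this assay.
Compound 1 `COc1ccc2c(c1)c(/C=N\NC(=O)c1cn(C)c3ccccc13)cn2Cc1ccc(Cl)cc1` gives 21200 nM in this assay.

Among the compounds with values here, all three numbers lie within the scatter of one another, so no compound can be set apart as stronger or weaker. Compound 2 stands second highest of the three; its nearest neighbour is compound 3, a step that reads a 1.1-fold lower number from compound 2 to compound 3 (0.03 log units; within the scatter) and that arises from methoxy in place of chloro on an aromatic carbon; compound 1, with a different substituent pattern on the shared core, sits a similar small distance on the other side.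

Compound 4 `O=C(N/N=C\c1cn(Cc2ccc(Cl)cc2)c2cc(F)ccc12)c1c[nH]c2ccc(Br)cc12` differs from compound 2 in one place: bromo in place of hydrogen on an aromatic carbon. None of the measured steps touches the indole portion of the amide, so nothing shown speaks directly to this change. With the measured steps all within the scatter, the step from compound 2 to compound 4 is expected to be no change at the digits printed from compound 2 to compound 4 (within the scatter), that is, no change beyond the scatter. Compound 4 is therefore estimated at 19500 nM in this assay, within a range from 8000 nM to 45000 nM.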

Compound 4, half-maximal inhibitory concentration: 12400 nM
Beside the measured number, compound 4's estimate is 1.6-fold (0.20 log units) above it; low and high end bracket the measured number.
By their numbers in this assay, from the lowest: compounds 4, 3, 2 and 1 (each within the scatter of the next).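

In this assay, within the data shown here, going from 1H-indol-3-yl to 5-bromo-1H-indol-3-yl gives a 1.6-fold lower number from compound 2 to compound 4 (0.20 log units; within the scatter), the first measured step at this part of the molecule, and like the one step measured earlier it stays within the scatter. A bromo on this aromatic carbon of the six-membered ring of carbon only is therefore tolerated without a step beyond the scatter, and none of the four compounds can yet be set apart from the others. Nothing shown gives a reason for this result.

From the compounds shown here alone, whether an amine or a carboxylic acid on the same aromatic carbon would give a step beyond the scatter remains open. Also open, going by these compounds, is whether the bromo would read the same alongside the methoxy of compound 3 in place of the chloro.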